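A few compounds are considered here, and "the series" means these few. Any claim that something is new, unique, unknown or untested is made for them only; others in the source may bear on it.

Measured so far in an ADME assay on S9 fraction from liver (Rattus norvegicus) for metabolic stability, with a stated time of 1 h; on this read-out lower numbers stand for a less stable compound and higher numbers for a more stable compound:
- compound 1 `N#Cc1cnc(NCc2cnccc2C(F)(F)F)cc1NC[C@H]1C[C@@H](O)C1`: 44%
- compound 2 `N#Cc1cnc(NCc2cnccc2C(F)(F)F)cc1N[C@H]1CC[C@@H](O)CC1`: 6%

Compound 2 holds the lower number of the two. Compound 3 `N#Cc1cnc(NCc2cnccc2C(F)(F)F)cc1N[C@H]1CC[C@H](O)CC1` keeps the atoms and bonds of compound 2: the two compounds have the same atoms and bonds and differ only in configuration as drawn: 2 of 2 stereo elements differ (all stereocentres are inverted: mirror images); a stereocentre at a saturated ring carbon is drawn s in compound 2 and r in compound 3; a stereocentre at a saturated ring carbon is drawn s in compound 2 and r in compound 3. Within the data shown here, the only measured step, a number 38 percentage points lower from compound 1 to compound 2 (beyond the scatter), is large, but it exchanged one group for another, so it cannot size a change of configuration alone. No such change has been measured here. Compound 2 leaves little room downward at 6%. The estimated step is therefore modest and upward: a number 8 percentage points higher from compound 2 to compound 3 (within the scatter). For compound 3 the expected value is 14%, with an estimated range from 3% to 40%.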

Compound 3, percent of the compound remaining: 25%
Beside the measured number, compound 3's estimate is 11 percentage points below it, within the range that was stated.
By their numbers in this assay, from the lowest: compound 2; then compound 3; then compound 1.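

In this assay, the 4-hydroxycyclohexyl group on the nitrogen turns out to be sensitive to configuration, with a number 19 percentage points higher from compound 2 to compound 3 (beyond the scatter). That gap can be assigned to the arrangement in space alone because of one fact: the fact that compounds 2 and 3 differ only in the configuration as drawn. The higher-scoring configuration still does not reach the (3-hydroxycyclobutyl)methyl group, with a number 19 percentage points lower from compound 1 to compound 3 (beyond the scatter), so the group exchange counts under either configuration.

Still open, on these data alone, is whether a methoxy group or an amine in place of the hydroxyl would shift the number. Also open, as far as these compounds go, is whether configuration matters as much on the cyclobutyl ring.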